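A few compounds are considered here, and "the series" means these few. Any claim that something is new, unique, unknown or untested is made for them only; others in the source may bear on it.

Measured in a functional assay on FM3A cells (Mus musculus) for cytotoxicity; on this read-out lower numbers stand for an effect already at smaller amounts and higher numbers for an effect only at larger amounts of compound:
- Compound 1 `COOC1(OOCCCc2ccccc2)CCCCCCCCCCC1`: 34000 nM
- Compound 2 `CCOC(C)OOC1(OOC)CCCCCCCCCCC1`: 12000 nM
- Compound 3 `C=CCCOOC1(OOC)CCCCCCCCCCC1`: 6000 nM

Compound 3 stands at 6000 nM, within the scatter of its nearest neighbour on these numbers: a 2.0-fold lower number from compound 2 to compound 3 (0.30 log units; within the scatter). That step put but-3-en-1-yl in place of 1-ethoxyethyl on an oxygen, so it says little about the chain now in question.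

The next compound is compound 4 `COOC1(OOCCC(=O)O)CCCCCCCCCCC1`. In it, carboxy stands in place of vinyl on a saturated chain carbon, two bonds along the chain from an oxygen on an unsaturated carbon (carboxy in place of vinyl on a saturated chain carbon, two bonds along the chain from an oxygen on an unsaturated carbon). The same difference can be read as but-3-en-1-yl to 2-carboxyethyl.

The closer guide is the step with vinyl at this place, which replaced benzyl: a 5.7-fold lower number from compound 1 to compound 3 (0.75 log units; beyond the scatter). It shows that the read-out can move beyond the scatter with a change at this position. Among the compounds with values here, no measured compound carries carboxy, however, so the direction is a judgement and remains uncertain.

A modest move toward a higher number is therefore expected, of about the size seen with compound 1, at 34000 nM, or somewhat smaller. The expected step is a 3.0-fold higher number from compound 3 to compound 4 (0.48 log units; beyond the scatter). For compound 4 the estimated value is 18000 nM, with an expected range from 6000 nM to 60000 nM.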

Compound 4, half-maximal effective concentration: 450 nM
Compound 4: middle estimate off by 40-fold (1.60 log units), on the high side; measured number below the stated range.
By their numbers in this assay, from the lowest: compound 4; then compounds 3 and 2 (each within the scatter of the next); then compound 1.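

In this assay, carboxy in place of vinyl, on a saturated chain carbon two bonds along the chain from an oxygen on an unsaturated carbon, gives a 13-fold lower number from compound 3 to compound 4 (1.12 log units; beyond the scatter), so this position can shift the read-out considerably further than the step from benzyl to vinyl, a 5.7-fold lower number from compound 1 to compound 3 (0.75 log units; beyond the scatter), had shown, and toward lower numbers rather than higher ones. The other two comparisons agree, with a 76-fold lower number from compound 1 to compound 4 (1.88 log units; beyond the scatter) for carboxy in place of benzyl and a 27-fold lower number from compound 2 to compound 4 (1.43 log units; beyond the scatter) for 2-carboxyethyl in place of 1-ethoxyethyl on an oxygen, which leaves compound 4 with the lowest number of the four, beyond the scatter of each of the others. Nothing at hand gives a reason for this drop.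

The compounds shown leave open whether the effect needs the free carboxy group itself, since neither its methyl ester nor a primary amide nor an amine appears at this place. They also leave open how the number responds to the length of the chain that carries the group, for instance a 3-carboxypropyl chain in place of 2-carboxyethyl.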